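The source may hold more compounds than are shown below. What is called first, only, known or untested is meant among the compounds shown, and "the series" means these compounds.

Of the compounds shown here, three have so far been read in a functional assay on B16-F0 cells (Mus musculus) for inhibition, read by CCK-8 assay, with a stated time of 48 h; a higher number here means a weaker inhibitor, a lower number a stronger inhibitor. Compound 1 `COc1cc(-c2cc3nccc(-c4cc(OC)c(OC)c(OC)c4)n3n2)cc(OC)c1OC` reports only a limit, > 10000 nM. Compound 2 `COc1cc(-c2ccnc3cc(-c4ccc(F)cc4)nn23)cc(OC)c1OC` gives 4540 nM, and compound 3 `Cn1ccc2cc(-c3cc4nccc(-c5ccc(F)cc5)n4n3)ccc21` gives 4780 nM. These two numbers lie within the usual scatter of each other, so compound 2 stands level with compound 3 and the two cannot be ranked.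

Compound 4 `COc1cc(-c2ccnc3cc(-c4ccc(C)c(C)c4)nn23)cc(OC)c1OC` has not yet been measured in this assay. It keeps the rest of compound 2 and carries 3,4-dimethylphenyl in place of 4-fluorophenyl on an aromatic carbon. For the measured compounds named here, no measured pair in this small set shows a change of this kind, so any expectation remains loose. The group that leaves and the group that enters each hold one six-membered aromatic ring of carbon only, and neither has a net charge. The expectation therefore rests on compound 2 at 4540 nM, the measured compound from which compound 4 differs in one place. The expected step is a 1.5-fold lower number from compound 2 to compound 4 (0.18 log units; within the scatter), a small one that leans toward a lower number and is not expected to go beyond the scatter. For compound 4 the estimated value is 3000 nM, with an expected range from 400 nM to 10000 nM.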

Compound 4, half-maximal inhibitory concentration: 391 nM
Estimate against measurement, compound 4: 7.7-fold (0.88 log units) above, and the stated range ends above it.
By their numbers in this assay, from the lowest: compound 4; then compounds 2 and 3 (each within the scatter of the next). At a limit, above all of these: compound 1.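

For the compounds shown here, until now the set held no pair differing in one place, so it could not show whether the aromatic carbon of the five-membered aromatic ring with 2 nitrogen responds to a change in its substituent in this assay. Compound 4 supplies that pair: with the rest of compound 2 kept, 3,4-dimethylphenyl in place of 4-fluorophenyl gives a 12-fold lower number from compound 2 to compound 4 (1.06 log units; beyond the scatter), a large step beyond the scatter. The aromatic ring, the absence of net charge and the counts of hydrogen-bond donors and acceptors are the same in both groups, so a change in substitution on that ring alone is enough to shift the reading this far at this position.

This single pair cannot separate the loss of fluorine from the gain of either methyl, and it leaves open how 3-methylphenyl, 4-methylphenyl, or a phenyl ring carrying an amine or a carboxylic acid would read at this place. Compound 1 remains a limit, not a number, and so supplies no step: the limit of > 10000 nM in this assay, at which 1 of the 4 values shown sits.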